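The source may hold more compounds than are shown below. What is called first, only, known or untested is meant among the compounds shown, and "the series" means these compounds.

Measured compounds:
- Compound 1, `Nc1scc(CN2CCN(c3c(F)cccc3F)CC2)c1C(=O)c1ccc(Cl)cc1`, gives -65% in a functional assay on CHO cells with adenosine receptor A1 (Homo sapiens) as the target, read by cAMP accumulation and immunoassay, with a stated time of 6 min, tested at 1 uM; on this read-out lower numbers stand for a stronger effect and higher numbers for a weaker effect at the one concentration tested.
- Compound 2, `Nc1scc(CN2CCN(c3cccc(F)c3F)CC2)c1C(=O)c1ccc(Cl)cc1`, gives -66% in this assay.

Among the compounds with values here, only two numbers are known so far. Within the data shown here, compound 2 and compound 1 sit within the scatter of each other, so on these two numbers compound 2 occupies no distinct place of its own; the only change measured, a number 1 percentage points lower from compound 1 to compound 2 (within the scatter), moved the read-out by less than one repeat measurement would.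

Compound 3, `Nc1scc(CN2CCN(c3cc(F)ccc3F)CC2)c1C(=O)c1ccc(Cl)cc1`, differs from compound 2 in a single spot: 2,5-difluorophenyl in place of 2,3-difluorophenyl on an amine nitrogen in a ring. The shared core, the carbonyl and the chlorine-bearing ring are untouched; only the pattern of the two fluorines on the ring carried by the ring nitrogen changes.

Among the measured compounds shown here, the one step that bears on this is a number 1 percentage points lower from compound 1 to compound 2 (within the scatter), which also swapped one difluorophenyl pattern for another at the same place and stayed within the scatter. On that basis no step beyond the scatter is expected, and the estimated change is a number 2 percentage points higher from compound 2 to compound 3 (within the scatter). Compound 3 is therefore expected to give about -64%, most likely between -77% and -51%.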

Compound 3, a percentage reported as activity, at one concentration (the size of the read-out at that concentration, not a potency): -59%
Compound 3: the middle estimate sits 5 percentage points below what was measured; the measured number falls inside the stated range.
By their numbers in this assay, from the lowest: compounds 2, 1 and 3 (each within the scatter of the next).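

In this assay, the 2,5-difluorophenyl group on the amine nitrogen in a ring gives a number 7 percentage points higher from compound 2 to compound 3 (within the scatter) and a number 6 percentage points higher from compound 1 to compound 3 (within the scatter). Within the data shown here, both steps are larger than the single step known before, yet neither leaves the scatter, so the three difluorophenyl patterns now on record cannot be told apart in this read-out, and none of them can be ranked above another. The new compound has the same atoms as compound 2, joined differently, so this result speaks only to where the two fluorines sit on this ring, and no measurement offered here accounts for the small differences among the numbers.

All three compounds carry two fluorines on this ring, so they show nothing about how much the fluorines themselves contribute, and a plain phenyl group without fluorine, a chlorophenyl, a methoxyphenyl or a pyridyl ring at the same nitrogen could read quite differently. As far as these compounds go, the shared core, the carbonyl and the chlorine-bearing ring also stay the same throughout, so the effect of changing any of those parts remains unknown.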